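The source may report more compounds than this note shows. Statements on the series, on what has been measured and on what is new or still open speak of the compounds shown alone.

Measured compounds:
- compound 1 `COc1cc(NC(=O)Nc2cc(Nc3cccc(C(C)(C)C)c3)ncn2)cc(OC)c1`: in a functional assay on PC-9 cells (Homo sapiens) for inhibition, read by MTT assay, with a stated time of 48 h, tested at 10 uM (on this read-out higher numbers stand for more inhibition at the one concentration tested (going by the name of the read-out) and lower numbers for less inhibition), compound 1 gives 68%
- compound 2 `CCc1ccc(Nc2cc(NC(=O)Nc3c(Cl)cccc3Cl)ncn2)cc1`: in this assay compound 2 gives 70.1%

Compound 1 shows the smaller of the two numbers, but its value and that of compound 2 lie within the scatter of each other, so no order between them can be read from the data. Compound 1 and compound 2 also differ in more than one place, so nothing is said here about any single change between them.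

The step that this account follows leads from compound 1 to compound 3 `COc1cc(NC(=O)Nc2cc(Nc3ccc(OC)c(C)c3)ncn2)cc(OC)c1`, which has not yet been measured in this assay. The difference between the two structures is 4-methoxy-3-methylphenyl in place of 3-(tert-butyl)phenyl on a nitrogen on an aromatic ring. Both groups are a single six-membered carbon ring carrying substituents, and the entering group brings one hydrogen-bond acceptor where the leaving one has none. Among the compounds with values here, no measured pair in the set shows this change, so no size of step for it is known.

The author expects the step from compound 1 to compound 3 to be small, around a number 6 percentage points lower from compound 1 to compound 3 (within the scatter), lying within the scatter or just beyond it in the downward direction. Compound 3 is accordingly estimated at 62%, with a range from 42% to 80%.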

Compound 3, a percentage reported as inhibition, at one concentration (the size of the read-out at that concentration, not a potency): 62%
Compound 3: middle estimate and measured number agree at the digits printed; low and high end bracket the measured number.
By their numbers in this assay, from the lowest: compounds 3, 1 and 2 (each within the scatter of the next).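

In this assay, replacing 3-(tert-butyl)phenyl with 4-methoxy-3-methylphenyl on a nitrogen on an aromatic ring comes to a number 6 percentage points lower from compound 1 to compound 3 (within the scatter). Within the data shown here, compounds 1 and 2 differ in more than one place, so this pair gives the first reading of a single change in the set: with the rest of compound 1 kept, this position takes a group bearing a hydrogen-bond acceptor in place of one with none, and the two compounds cannot be told apart on this read-out. Nothing available here accounts for this result, and the pair alone cannot supply an explanation.

The compounds shown leave open how the read-out would respond to an amine or a carboxylic acid on this phenyl ring, and whether the methoxy and the methyl would read the same if each stood alone. Since every number comes from one concentration, they also leave open whether compound 1 and compound 3 would differ in potency across a range of concentrations.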